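Halogen swap on two related cores: migration notes

The source may report more compounds than this note shows. Statements on the series, on what has been measured and on what is new or still open speak of the compounds shown alone.

Measured so far in a functional assay on MDA-MB-231 cells (Homo sapiens), read by microscopy and transwell migration, with a stated time of 24 h; on this read-out lower numbers stand for stronger inhibition and higher numbers for weaker inhibition:
compound 1 `O=C(Nc1nc(-c2ccc(Br)cc2)cs1)c1ccccc1` gives 9500 nM
compound 2 `O=C(Nc1nc(-c2cccc(Cl)c2)cs1)c1ccccc1` gives 123 nM
compound 3 `Cn1c(-c2ccc(Br)cc2)cs/c1=N\C(=O)c1ccccc1` gives 125 nM

Within the core of compound 1, one change is recorded: 3-chlorophenyl in place of 4-bromophenyl on an aromatic carbon. Its step is a 77-fold lower number from compound 1 to compound 2 (1.89 log units; beyond the scatter). Compound 3 carries a different core; how it differs from compound 1 is not broken down here. Compound 3 and compound 2 give numbers within the scatter of each other.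

Compound 4 `Cn1c(-c2cccc(Cl)c2)cs/c1=N\C(=O)c1ccccc1` is not yet measured in this assay. It applies the same kind of change to compound 3: 3-chlorophenyl in place of 4-bromophenyl on an aromatic carbon. The surroundings differ, in that the aromatic carbon is next to the ring atom that bears a methyl group here, whereas in compound 1 it was two ring bonds from the ring atom that bears a group of 9 heavy atoms. Since compound 3 already gives 125 nM, a step as large as a 77-fold lower number from compound 1 to compound 2 (1.89 log units; beyond the scatter) is not expected to repeat. The expected step is a 2.8-fold lower number from compound 3 to compound 4 (0.44 log units; beyond the scatter), and compound 4 is estimated at 45 nM, from 8 nM to 250 nM.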

Compound 4, half-maximal inhibitory concentration: 367 nM
The estimate for compound 4 lay 8.2-fold (0.91 log units) below the measured number; the whole stated range lies below it.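

In this assay the swap from 4-bromophenyl to 3-chlorophenyl on the core of compound 3 gives a 2.9-fold higher number from compound 3 to compound 4 (0.47 log units; beyond the scatter) and not the drop seen on the core of compound 1. The same change therefore runs in opposite directions on the two cores, and the two steps differ: the same change on two cores in this assay, a 77-fold lower number (1.89 log units; beyond the scatter) from compound 1 to compound 2 and a 2.9-fold higher number (0.47 log units; beyond the scatter) from compound 3 to compound 4, 230-fold (2.36 log units) apart, beyond the scatter of two such steps. This shows that the result of this change on one core does not predict its result on the other, but it does not show which difference between the cores separates the two outcomes.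

The swap alters both the halogen and its place on the phenyl ring, so 3-bromophenyl and 4-chlorophenyl on each core would be needed to separate the two. Also open, from the compounds shown here alone, is whether an ethyl group or a longer chain in place of the methyl group on the ring nitrogen would follow either trend.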